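A few compounds are considered here, and "the series" means these few. Any claim that something is new, unique, unknown or untested is made for them only; others in the source may bear on it.

Compound 1 `FC(F)(F)c1ccc(-c2ccc(-c3ccc(-c4nc5ccccc5[nH]4)cc3)cc2)cc1`: 41400 nM
Compound 2 `Oc1ccc(-c2ccc(-c3ccc(-c4nc5ccccc5[nH]4)cc3)cc2)cc1`: 30500 nM

In a functional assay on MCF7 cells (Homo sapiens) for inhibition, read by sulforhodamine B assay (on this read-out lower numbers stand for stronger inhibition of growth and higher numbers for weaker inhibition of growth), compound 2 has only compound 1 for comparison, and the two numbers lie within the scatter of each other. Compound 3 `Cc1ccc2[nH]c(-c3ccc(-c4ccc(-c5ccc(O)cc5)cc4)cc3)nc2c1` differs from compound 2 by methyl in place of hydrogen on an aromatic carbon. For the measured compounds named here, the one measured step (a 1.4-fold lower number from compound 1 to compound 2 (0.13 log units; within the scatter)) is a different change at a different place and stays within the scatter, so it offers only weak guidance. No step beyond the scatter is expected in this assay from this change. Compound 3 is estimated at 28000 nM with an expected range from 13000 nM to 60000 nM as its limits. An estimated 1.1-fold lower number from compound 2 to compound 3 (0.04 log units; within the scatter) stays within the scatter.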

Compound 3, concentration for 50% growth inhibition: 12100 nM
Compound 3: middle estimate off by 2.3-fold (0.36 log units), on the high side; the measured number lies below the stated range.
By their numbers in this assay, from the lowest: compound 3; then compounds 2 and 1 (each within the scatter of the next).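

In this assay, methyl in place of hydrogen on an aromatic carbon of the six-membered ring in the fused system gives a 2.5-fold lower number from compound 2 to compound 3 (0.40 log units; beyond the scatter), a modest step. For the compounds shown here, this is the first change to go beyond the scatter, and this position, unlike the exchange of trifluoromethyl for hydroxy at the other end of the molecule, responds measurably. No measured data at hand account for the step.

From the compounds shown here alone, whether ethyl, methoxy or an amine at this carbon would extend, match or reverse the step remains open. Also open, going by these compounds, is whether methyl gives a similar step with trifluoromethyl in place of hydroxy.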